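A few compounds are considered here, and "the series" means these few. Any claim that something is new, unique, unknown or untested is made for them only; others in the source may bear on it.

For the measured compounds named here, compound 3 `CN1CCN(c2ccc(Nc3nc(-c4cccc(NC(=O)c5ccccc5)c4)sc3C(=O)O)cc2)CC1` gives 11.9% in a functional assay on Raji cells (Homo sapiens) for antiproliferative activity, read by CCK-8 assay, with a stated time of 72 h, tested at 40 uM (a higher number here means more inhibition at the concentration tested (going by the name of the read-out), a lower number less inhibition), the smallest of the three numbers measured so far. Compound 1 `CCOC(=O)c1sc(-c2cccc(NC(=O)c3ccc(F)cc3)c2)nc1Nc1ccc(N2CCN(C)CC2)cc1` gives 16.8%, which lies within the scatter of compound 3, so the two are not distinguished; compound 2 `CCOC(=O)c1sc(-c2cccc(NC(=O)c3ccccc3)c2)nc1Nc1ccc(N2CCN(C)CC2)cc1` gives 42% and stands well beyond both. Compound 4 `CN1CCN(c2ccc(Nc3nc(-c4cccc(NC(=O)c5ccc(Cl)cc5)c4)sc3C(=O)O)cc2)CC1` has not yet been measured. It differs from compound 3 by chloro in place of hydrogen on an aromatic carbon: the chloro enters on an aromatic carbon of the six-membered carbon-only ring, para to a large group, so that the benzamido becomes ((4-chlorophenyl)carbonyl)amino.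

Two steps are known. The step of a number 25.2 percentage points higher from compound 1 to compound 2 (beyond the scatter) concerns the same carbon and is the one that bears here: a fluoro giving way to hydrogen there raised the number. The step of a number 30.1 percentage points lower from compound 2 to compound 3 (beyond the scatter) concerns the ester and does not touch the carbon now being changed. Reading the first step in reverse, a halogen entering at that carbon would be expected to lower the number, though compound 3 already sits close to the floor of the percentage scale, leaving little room for a large fall. A step of a number 4.9 percentage points lower from compound 3 to compound 4 (within the scatter) is therefore expected, downward or not beyond the scatter. Compound 4 is estimated at 7%, with a range from 0% to 20%.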

Compound 4, a percentage reported as inhibition, at one concentration (the size of the read-out at that concentration, not a potency): 90.9%
The estimate for compound 4 lay 83.9 percentage points below the measured number; the whole stated range lies below it.
By their numbers in this assay, from the lowest: compounds 3 and 1 (each within the scatter of the next); then compound 2; then compound 4.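

With the carboxylic acid kept, a number 79 percentage points higher from compound 3 to compound 4 (beyond the scatter) in this assay shows that this single change on an aromatic carbon, para to a large group, can move the number strongly upward, so a halogen here need not lower it and acid-bearing compounds are not confined to low numbers. The earlier fall at this carbon, read in reverse from a number 25.2 percentage points higher from compound 1 to compound 2 (beyond the scatter), involved fluoro in the ethyl ester, so the two steps differ in both the halogen and the group on the carbonyl, and these compounds do not show which difference accounts for their opposite directions. Nothing available explains the size of the rise.

Still open, as far as these compounds go, is whether the rise belongs to chloro itself or to halogens at this carbon in general: fluoro or bromo on the acid, and chloro on the ethyl ester, would separate these cases. A methyl, a methoxy or an amine at the same carbon would show whether hydrogen is the exception there, and a read-out at a single concentration gives no potency for any of these compounds.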